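Benzyl in Place of Cyclohexyl on a Ring-Bound Nitrogen

The compounds below may be only part of what the source reports. "The series", "measured", "known", "first", "only" and "open" are said of these compounds alone.

Compound 1, `CCCNc1cc(-c2ccccc2)nc2cc(OC)cc(OC)c12`, gives 9770 nM in a functional assay on DU-145 cells (Homo sapiens) for inhibition, read by MTT assay, with a stated time of 72 h; a lower number here means a stronger inhibitor, a higher number a weaker inhibitor.
Compound 2, `CCCCNc1cc(-c2ccccc2)nc2cc(OC)cc(OC)c12`, gives 4630 nM.
Compound 3, `COc1cc(OC)c2c(NC3CCCCC3)cc(-c3ccccc3)nc2c1`, gives 5470 nM.

Among these three, compound 3 stands second highest. The nearest measured step is a 1.2-fold higher number from compound 2 to compound 3 (0.07 log units; within the scatter), and the furthest is a 1.8-fold lower number from compound 1 to compound 3 (0.25 log units; within the scatter); both lie within the scatter, so compound 3 cannot be placed above or below either partner with confidence. Within the data shown here, the one step that does reach beyond the scatter is a 2.1-fold lower number from compound 1 to compound 2 (0.32 log units; beyond the scatter), a modest change.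

Compound 4, `COc1cc(OC)c2c(NCc3ccccc3)cc(-c3ccccc3)nc2c1`, differs from compound 3 by benzyl in place of cyclohexyl on a nitrogen on an aromatic ring. All three measured steps concern the same nitrogen substituent, so they bear on this change, but each swaps one saturated group for another, and none exchanges a saturated ring for an aromatic one. Among the measured compounds shown here, the measured record therefore gives no direct guide to direction, and the only step beyond the scatter was modest. The expectation is accordingly a step of no more than modest size, with direction open: a 1.2-fold lower number from compound 3 to compound 4 (0.08 log units; within the scatter) is expected. Compound 4 is estimated at 4500 nM, within a range from 1800 nM to 11000 nM.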

Compound 4, half-maximal inhibitory concentration: 10100 nM
Compound 4: the middle estimate sits 2.2-fold (0.35 log units) below what was measured; the measured number falls inside the stated range.
By their numbers in this assay, from the lowest: compounds 2, 3, 1 and 4 (each within the scatter of the next, the first and the last beyond it).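

Compound 4 is the only one of the four that carries an aromatic ring on this nitrogen substituent, and in this assay exchanging the saturated ring for it gives a 1.8-fold higher number from compound 3 to compound 4 (0.27 log units; within the scatter), a step that stays within the scatter. Against the straight chains, the benzyl group gives a 1.0-fold higher number from compound 1 to compound 4 (0.01 log units; within the scatter), again within the scatter, and a 2.2-fold higher number from compound 2 to compound 4 (0.34 log units; beyond the scatter), a modest step beyond it, so the benzyl group can be told apart only from butyl, and the number is higher with benzyl. Nothing measured here offers a reason for that gap.

As far as these compounds go, with these four groups, the position shows only small steps, and it remains open whether a longer chain such as hexyl would lower the number further than butyl or would raise it again. Also open, from the compounds shown here alone, is how a chain ending in an amine or a hydroxyl group, or a benzyl ring bearing a methoxy group or a chlorine atom, would behave at this nitrogen.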